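A few compounds are considered here, and "the series" means these few. Any claim that something is new, unique, unknown or untested is made for them only; others in the source may bear on it.

Notes on the series. Compound 1 `c1coc(-c2ccccc2OCC2=NCCN2)c1` and compound 2 `c1ccc(-c2ccns2)c(OCC2=NCCN2)c1` share one core and differ only in the five-membered ring attached to it. In a functional assay with Alpha-1A adrenergic receptor (Homo sapiens) as the target, read by calcium flux (a higher number here means a larger maximal response, a lower number a smaller maximal response), compound 1 gives 106%, and compound 2 gives 99%. The step of a number 7 percentage points lower from compound 1 to compound 2 (within the scatter) exchanges one five-membered aromatic ring for another without moving the response beyond the scatter. Among the measured compounds shown here, compound 2 holds the lower of the two numbers measured so far, though compound 1 lies within the scatter of it, so the two cannot be separated.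

Compound 3 `c1ccc(-c2ncc[nH]2)c(OCC2=NCCN2)c1` has not yet been measured in this assay. It differs from compound 2 by 1H-imidazol-2-yl in place of 1,2-thiazol-5-yl on an aromatic carbon. For the measured compounds named here, the only step so far that bears on replacing one five-membered aromatic ring with another is a number 7 percentage points lower from compound 1 to compound 2 (within the scatter), which stayed within the scatter; no measured step so far brings a hydrogen-bond donor onto this ring, so that part of the change is untested. On that basis no step beyond the scatter is expected, and the estimated step of a number 4 percentage points lower from compound 2 to compound 3 (within the scatter) is accordingly small. Compound 3 is expected to give 95%, within a range from 75% to 110%.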

Compound 3, largest response reached (reported as maximum), in percent of the reference or control that the assay uses: 122%
The estimate for compound 3 lay 27 percentage points below the measured number; the measured number lies above the stated range.
By their numbers in this assay, from the lowest: compounds 2 and 1 (each within the scatter of the next); then compound 3.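

Working from the place on the aromatic carbon ortho to a group of 7 heavy atoms, the step of a number 23 percentage points higher from compound 2 to compound 3 (beyond the scatter) shows that in this assay an exchange of one five-membered aromatic ring for another can move the maximal response beyond the scatter, which the earlier pair did not show. The step of a number 16 percentage points higher from compound 1 to compound 3 (beyond the scatter) is also beyond the scatter, so 1H-imidazol-2-yl stands apart from both furan-2-yl and 1,2-thiazol-5-yl, and the gain comes with no change in ring size or in heavy-atom count relative to 1,2-thiazol-5-yl. The change from 1,2-thiazol-5-yl to 1H-imidazol-2-yl also goes from 0 hydrogen-bond donors to 1, but no supporting data accompany this result, so that coincidence remains an observation only.

The compounds shown leave open whether the ring hydrogen on nitrogen matters or the ring as a whole does, a question that 1-methyl-1H-imidazol-2-yl at the same place would address. They also leave open whether a five-membered ring is needed at all, as a comparison with pyridin-2-yl or a simple aminomethyl group would show.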